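A few compounds are considered here, and "the series" means these few. Any claim that something is new, unique, unknown or untested is made for them only; others in the source may bear on it.

The series shares one core, carried by compound 1 `COc1cc2nc(/C=C/c3ccccc3)nc(N3CCC(CCNS(N)(=O)=O)CC3)c2cc1OC`, compound 2 `COc1cc2ncnc(N3CCC(CCNC(C)=O)CC3)c2cc1OC` and compound 3 `COc1cc2ncnc(N3CCC(CCN)CC3)c2cc1OC`. In an assay on cells for inhibition of Ectonucleotide pyrophosphatase/phosphodiesterase family member 1 (Homo sapiens), with a stated time of 60 min (a lower number here means a stronger inhibitor, a higher number a weaker inhibitor), compound 1 gives 1840 nM, the only figure in hand. Within the data shown here, for compound 2 this assay records "not determined" (no result reported), so no number places it against compound 1 and no measured step reaches it. The change from compound 2 to compound 3 is hydrogen in place of acetyl on an amine nitrogen. Among the measured compounds shown here, no step between measured compounds exists for this change, and neither compound carries the groups that set compound 1 apart, so there is no ground for saying how large a step in this assay to expect, or in which direction; an effect beyond the usual scatter is possible but cannot be sized from what has been measured. Compound 3 is therefore estimated in this assay at 3000 nM, within a range from 400 nM to 25000 nM.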

Compound 3, inhibition constant: 699 nM
For compound 3 the middle estimate is 4.3-fold (0.63 log units) above the measured one; low and high end bracket the measured number.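

In this assay, among these compounds, compound 3 gives 699 nM and compound 2 has no number, so no step between compound 2 and compound 3 can be read. The compounds shown leave open how far hydrogen in place of acetyl on that amine nitrogen shifts the inhibition constant. No evidence bears on this result.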